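From Aminoethyl to Trifluoromethylphenyl on the Amide Nitrogen

The source may hold more compounds than are shown below. What is called first, only, known or untested is meant among the compounds shown, and "the series" means these compounds.

In a functional assay on HepG2 cells (Homo sapiens) for antiproliferative activity, read by MTT assay, with a stated time of 48 h (a lower number here means a stronger inhibitor, a higher number a weaker inhibitor), compound 1 `CCn1c(C(=O)NCCN(C)C)ccc1C(CC)(CC)c1ccc(OCCC(O)(CC)CC)c(C)c1` gives 240 nM and compound 2 `CCN(CC)CCNC(=O)c1ccc(C(CC)(CC)c2ccc(OCCC(O)(CC)CC)c(C)c2)n1CC` gives 230 nM with a 1.0-fold lower number from compound 1 to compound 2 (0.02 log units; within the scatter) between them, so the two cannot be ranked. Compound 3 `CCn1c(C(=O)NCCN)ccc1C(CC)(CC)c1ccc(OCCC(O)(CC)CC)c(C)c1` stands highest of the three at 1590 nM and is the weakest inhibitor here. Amino in place of dimethylamino gave a 6.6-fold higher number from compound 1 to compound 3 (0.82 log units; beyond the scatter) and amino in place of diethylamino gave a 6.9-fold higher number from compound 2 to compound 3 (0.84 log units; beyond the scatter) in these comparisons.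

Compound 4 `CCn1c(C(=O)Nc2cccc(C(F)(F)F)c2)ccc1C(CC)(CC)c1ccc(OCCC(O)(CC)CC)c(C)c1` has not been measured. Its difference from compound 3 reads 3-(trifluoromethyl)phenyl in place of 2-aminoethyl on an amide-type nitrogen and amounts to 3-(trifluoromethyl)phenyl in place of 2-aminoethyl on an amide-type nitrogen. For the measured compounds named here, no measured step makes this kind of change, since all of them only alter the amine at the end of the chain. The modest steps give a rough size for what such a swap can do in this assay but no firm direction, so only a small fall in the number is expected. The expected size is a 1.6-fold lower number from compound 3 to compound 4 (0.20 log units; within the scatter) in this estimate. Compound 4 is estimated at 1000 nM with a wide expected range from 200 nM to 6000 nM at this stage.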

Compound 4, half-maximal inhibitory concentration: > 50000 nM
Compound 4 gave a limit, no number (the forecaster's own chance of this, stated with the estimate: 10%); at least 50-fold (1.69 log units) between middle value and limit.
By their numbers in this assay, from the lowest: compounds 2 and 1 (each within the scatter of the next); then compound 3. At a limit, above all of these: compound 4.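

In this assay compound 4 gives a limit of the assay and not a number: the limit of > 50000 nM in this assay, at which 1 of the 4 values shown sits.

The earlier steps shown here changed only the amine at the end of the chain, whereas this change replaces the whole chain on the amide-type nitrogen and gives far larger steps: an at least 31-fold higher number from compound 3 to compound 4 (1.49 log units; beyond the scatter) and an at least 210-fold higher number from compound 2 to compound 4 (2.33 log units; beyond the scatter) and also an at least 200-fold higher number from compound 1 to compound 4 (2.31 log units; beyond the scatter) on the same scale. This position therefore matters much more than the amine steps alone suggested, since compounds 1, 2 and 3, each with an amine-bearing chain, give numbers and compound 4, with its aromatic ring and no amine, does not.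

The change removes the amine and adds the ring and the trifluoromethyl group all at once, so the compounds shown cannot separate these parts. As far as these compounds go, a plain phenyl, a 2-hydroxyethyl chain or a 3-aminophenyl group on the same nitrogen remains open.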